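Compound 3 to compound 4: clearance working notes

The source may report more compounds than this note shows. Statements on the series, on what has been measured and on what is new or still open speak of the compounds shown alone.

Measured in an ADME assay on microsomes from liver (Homo sapiens) for metabolic stability, read by LC-MS, tested at 1 uM; on this read-out lower numbers stand for slow clearance and higher numbers for fast clearance:
- compound 1 `NCCCCCOc1ccc([C@H]2CC[C@]3(CC2)OOC2(O3)C3CC4CC(C3)CC2C4)cc1`: < 7 mL.min-1.g-1 (a limit)
- compound 2 `O=S(=O)(c1ccc([C@H]2CC[C@]3(CC2)OOC2(O3)C3CC4CC(C3)CC2C4)cc1)N1CCNCC1`: 16 mL.min-1.g-1
- compound 3 `NC(=O)C1CCN(Cc2ccc([C@H]3CC[C@]4(CC3)OOC3(O4)C4CC5CC(C4)CC3C5)cc2)CC1`: 10 mL.min-1.g-1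

In this assay, for the measured compounds named here, compound 3 gives 10 mL.min-1.g-1, and the only other number is that of compound 2. The nearest measured step is a 1.6-fold lower number from compound 2 to compound 3 (0.20 log units; within the scatter). Compound 1 offers no number, only (the limit of < 7 mL.min-1.g-1 in this assay, at which 1 of the 3 values shown sits).

Compound 4 `c1cc([C@H]2CC[C@]3(CC2)OOC2(O3)C3CC4CC(C3)CC2C4)ccc1OC1CCNCC1` differs from compound 3 in one place: (piperidin-4-yl)oxy in place of (4-carbamoylpiperidin-1-yl)methyl on an aromatic carbon, para to a large group ((piperidin-4-yl)oxy in place of (4-carbamoylpiperidin-1-yl)methyl on an aromatic carbon). Going by the values given here, compound 1 is the one measured compound that also carries an oxy group at this place, (5-aminopentyl)oxy, so the step that bears most closely is an at least 1.4-fold higher number from compound 1 to compound 3 (0.15 log units; that floor lies within the scatter). The other step away from compound 1 is an at least 2.2-fold higher number from compound 1 to compound 2 (0.35 log units; beyond the scatter), which leads to (piperazin-1-yl)sulfonyl and not to the change at hand. Neither step points to a large move, and a small drop is expected in this assay. The expected step is a 1.3-fold lower number from compound 3 to compound 4 (0.10 log units; within the scatter), which would stay inside the scatter. For compound 4 the estimated value is 8 mL.min-1.g-1, with an expected range of 5 mL.min-1.g-1 to 15 mL.min-1.g-1.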

Compound 4, intrinsic clearance in microsomes: 15 mL.min-1.g-1
Compound 4: the middle estimate sits 1.9-fold (0.27 log units) below what was measured; low and high end bracket the measured number.
By their numbers in this assay, from the lowest: compounds 3, 4 and 2 (each within the scatter of the next). At a limit, below all of these: compound 1.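

For the compounds shown here, at this aromatic carbon, para to a large group, (piperidin-4-yl)oxy in place of (4-carbamoylpiperidin-1-yl)methyl gives a 1.5-fold higher number from compound 3 to compound 4 (0.18 log units; within the scatter) in this assay, and the comparison with the sulfonyl-linked group gives a 1.1-fold lower number from compound 2 to compound 4 (0.03 log units; within the scatter), so three different groups at this place now stand with no step among them beyond the scatter. Going by these compounds alone, the oxy link alone therefore does not tie a compound to the low end of this read-out, since the one step beyond the scatter lies between two oxy compounds: an at least 2.1-fold higher number from compound 1 to compound 4 (0.33 log units; beyond the scatter), with piperidin-4-yl in place of 5-aminopentyl on the oxygen. The entry for compound 1 is a limit and not a number, so that step gives only a floor: the limit of < 7 mL.min-1.g-1 in this assay, at which 1 of the 4 values shown sits.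

The compounds shown leave open whether the difference between compound 1 and compound 4 follows the ring or the length of the group on the oxygen, and a 3-aminopropyl chain on the same oxygen would help separate the two. They also leave open where a tetrahydropyran-4-yl group, with oxygen in place of the ring nitrogen, would fall relative to compound 4.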